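Swapping an acetylpyrazole for a pyridine on a shared core

This account rests on a few compounds, and the source may have more. Where it says the series, first, only, none or still open, it means among the compounds named here.

Three compounds share one core and differ only in the ring attached on an aromatic carbon of a six-membered aromatic ring of carbon only, para to a large group. Compound 1 `CNC(=O)N1CCCc2ccc(NC(=O)c3ccc(-c4ccccc4)cc3)cc21` carries a phenyl there, compound 2 `CNC(=O)N1CCCc2ccc(NC(=O)c3ccc(-c4cnn(C)c4)cc3)cc21` a 1-methyl-1H-pyrazol-4-yl, and compound 3 `CNC(=O)N1CCCc2ccc(NC(=O)c3ccc(-c4ccn(C(C)=O)n4)cc3)cc21` a 1-acetyl-1H-pyrazol-3-yl. In a functional assay on MV4-11 cells (Homo sapiens) for antiproliferative activity, with a stated time of 6 days, tested at 6.25 uM (a higher number here means a stronger effect of the compound at the concentration tested, a lower number a weaker effect), compound 1 gives 74.3%, compound 2 gives 94.4% and compound 3 gives 91.4%. Compound 3 therefore stands second highest of the three numbers, close to compound 2 and well clear of compound 1.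

The steps behind this are a number 20.1 percentage points higher from compound 1 to compound 2 (beyond the scatter) and a number 17.1 percentage points higher from compound 1 to compound 3 (beyond the scatter), while a number 3 percentage points lower from compound 2 to compound 3 (within the scatter). Both five-membered rings thus outperformed phenyl by a similar margin, and the choice between them made no difference.

Compound 4 `CNC(=O)N1CCCc2ccc(NC(=O)c3ccc(-c4ccccn4)cc3)cc21` brings a new ring: pyridin-2-yl in place of 1-acetyl-1H-pyrazol-3-yl on an aromatic carbon. For the measured compounds named here, a six-membered ring with one nitrogen sits between the phenyl of compound 1 and the pyrazoles of compounds 2 and 3, and no measured step covers exactly this exchange. A modest drop is therefore expected, a number 9.4 percentage points lower from compound 3 to compound 4 (within the scatter). Compound 4 is estimated to give 82% in this assay, within a range from 65% to 95%.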

Compound 4, a percentage reported as inhibition, at one concentration (the size of the read-out at that concentration, not a potency): 79.2%
The estimate for compound 4 lay 2.8 percentage points above the measured number; the measured number falls inside the stated range.
By their numbers in this assay, from the lowest: compounds 1 and 4 (each within the scatter of the next); then compounds 3 and 2 (each within the scatter of the next).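

In this assay, the gain seen with the two pyrazoles does not carry over to the pyridin-2-yl ring: the change gives a number 12.2 percentage points lower from compound 3 to compound 4 (beyond the scatter) and a number 15.2 percentage points lower from compound 2 to compound 4 (beyond the scatter) when set against those rings, while it gives a number 4.9 percentage points higher from compound 1 to compound 4 (within the scatter) when set against phenyl. Adding one ring nitrogen to phenyl is therefore not enough on its own to reach the level of the pyrazoles, and among these four compounds both five-membered rings sit above both six-membered rings, with no compound going against that split. No available measurement explains why the two ring types separate in this way.

On these data alone, it remains open whether the pyridine result depends on where the ring is attached, which pyridin-3-yl or pyridin-4-yl would test, and whether a plain pyrazole with a hydrogen on its ring nitrogen would match the methyl and acetyl versions. A saturated ring such as morpholine or piperazine at the same place would show whether an aromatic ring is needed there at all.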